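Clearance of a fused-core series: lactam replaces benzamide

The source may report more compounds than this note shows. Statements on the series, on what has been measured and on what is new or still open speak of the compounds shown alone.

Measured compounds:
Compound 1 `O=C1c2ccccc2CN1c1cnc(NCc2c(F)ccc3c2CCO3)n2cnnc12`: 13 mL.min-1.g-1
Compound 2 `Fc1ccc2c(c1CNc1ncc(Oc3ccccc3)c3nncn13)CCO2`: 18 mL.min-1.g-1
Compound 3 `O=C(Nc1cnc(NCc2c(F)ccc3c2CCO3)n2cnnc12)c1ccccc1`: 10 mL.min-1.g-1

In an ADME assay on microsomes from liver (Homo sapiens) for metabolic stability, read by LC-MS, using NADPH, with stated times of 5 min and 30 min, tested at 1 uM (on this read-out lower numbers stand for slow clearance and higher numbers for fast clearance), compound 3 gives the lowest of the three numbers, although its steps to the other two lie within the scatter: a 1.3-fold lower number from compound 1 to compound 3 (0.11 log units; within the scatter) and a 1.8-fold lower number from compound 2 to compound 3 (0.26 log units; within the scatter). Compound 4 `CC1(C)CC(=O)N(c2cnc(NCc3c(F)ccc4c3CCO4)n3cnnc23)C1` differs from compound 3 by 4,4-dimethyl-2-oxopyrrolidin-1-yl in place of benzamido on an aromatic carbon. The step from compound 1 to compound 3 bears most directly on this change, as compound 1 also carries a five-membered non-aromatic ring with one hetero atom at this position, and that step was within the scatter; a 1.4-fold higher number from compound 1 to compound 2 (0.14 log units; within the scatter) was likewise small. No step beyond the scatter is therefore expected for compound 4, whose number in this assay is estimated at 12 mL.min-1.g-1, between 6 mL.min-1.g-1 and 24 mL.min-1.g-1, meaning a 1.2-fold higher number from compound 3 to compound 4 (0.08 log units; within the scatter).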

Compound 4, intrinsic clearance in microsomes: 16 mL.min-1.g-1
For compound 4 the middle estimate is 1.3-fold (0.12 log units) below the measured one; the range from low to high includes it.
By their numbers in this assay, from the lowest: compounds 3, 1, 4 and 2 (each within the scatter of the next).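

In this assay the step to 4,4-dimethyl-2-oxopyrrolidin-1-yl, a group with no aromatic ring and no hydrogen-bond donor, stays small against benzamido (a 1.6-fold higher number from compound 3 to compound 4 (0.20 log units; within the scatter)) and against the other two groups (a 1.1-fold lower number from compound 2 to compound 4 (0.05 log units; within the scatter); a 1.2-fold higher number from compound 1 to compound 4 (0.09 log units; within the scatter)). At this position on the shared core, losing the six-membered aromatic ring of carbon only therefore gives no step beyond the scatter. From the compounds shown here alone, whether an amine or a carboxylic acid here would give such a step stays open, as does the contribution of the two methyl groups. Nothing at hand explains these numbers.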